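Lengthening the Chain on a Cholesterol Acyltransferase Inhibitor

The source may hold more compounds than are shown below. What is called first, only, known or untested is meant among the compounds shown, and "the series" means these compounds.

Measured compounds:
Compound 1, `CCCCCCN1NN=C(NC(=O)Nc2c(C(C)C)cccc2C(C)C)N1`, gives 73 nM in an assay on microsomes from intestine for inhibition of acyl-CoA:cholesterol acyltransferase (Oryctolagus cuniculus); on this read-out higher numbers stand for weaker inhibition and lower numbers for stronger inhibition.
Compound 2, `CCCCCCCCCCCCN1NN=C(NC(=O)Nc2c(C(C)C)cccc2C(C)C)N1`, gives 14 nM in this assay.

Among the measured compounds shown here, compound 2 holds the lowest of the two numbers measured so far, and its only neighbour is compound 1; the step between them, a 5.2-fold lower number from compound 1 to compound 2 (0.72 log units; beyond the scatter), came from a hexyl in place of hydrogen on a saturated chain carbon, six bonds along the chain from an amine nitrogen in a ring. Compound 3, `CCCCCCCCCCCCCCN1NN=C(NC(=O)Nc2c(C(C)C)cccc2C(C)C)N1`, carries the same shared core and differs from compound 2 only in this way: ethyl in place of hydrogen on a saturated chain carbon, ten or more bonds along the chain from an amine nitrogen in a ring. For the measured compounds named here, the one measured step that bears on it is a 5.2-fold lower number from compound 1 to compound 2 (0.72 log units; beyond the scatter), which belongs to a much longer extension of the same chain. The change to compound 3 is a shorter extension placed further out, so a smaller step in this assay is expected, in the lower direction, and it may well stay within the scatter. Compound 3 is therefore estimated at 10 nM in this assay, with a likely range from 4 nM to 30 nM. This estimate means an expected step of a 1.4-fold lower number from compound 2 to compound 3 (0.15 log units; within the scatter).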

Compound 3, half-maximal inhibitory concentration: 12 nM
The estimate for compound 3 lay 1.2-fold (0.08 log units) below the measured number; low and high end bracket the measured number.
By their numbers in this assay, from the lowest: compounds 3 and 2 (each within the scatter of the next); then compound 1.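

Among the compounds shown here, at this far stretch of the chain, ethyl in place of hydrogen gives a 1.2-fold lower number from compound 2 to compound 3 (0.07 log units; within the scatter) in this assay against a 5.2-fold lower number from compound 1 to compound 2 (0.72 log units; beyond the scatter) for the hexyl extension, so compound 2 and compound 3 cannot be told apart, and the earlier compounds could not show that added chain length can stop making a readable difference. Read across the whole octyl difference, the chain gives a 6.1-fold lower number from compound 1 to compound 3 (0.78 log units; beyond the scatter) and this step is close in size to the hexyl step alone, so among these three compounds the readable difference lies between compound 1 and compound 2, while the further ethyl extension adds none that stands clear of the scatter. Nothing measured here explains why the chain behaves this way.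

On these data alone, whether a still longer chain would leave the number where it stands or move it remains open, since only straight saturated chains are in view. A chain ending in a carboxylic acid or an amine, or one carrying a phenyl ring at its far end, would test whether this position tolerates anything other than plain carbon.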